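The compounds below may be only part of what the source reports. "The series", "measured", "known", "first", "only" and "open" are said of these compounds alone.

Compound 3 `COc1ccc(C(=O)/C=C/c2cc(-c3cc(OC)c(OC)c(OC)c3)n[nH]2)cc1OC` gives 6250 nM in a functional assay on SK-MEL-28 cells (Homo sapiens) for inhibition, read by sulforhodamine B assay, with a stated time of 48 h (a higher number here means that more compound is tolerated, a lower number that less compound is tolerated), the lowest of the two numbers measured there. Compound 2 `COc1ccc(-c2cc(/C=C/C(=O)c3cc(OC)c(OC)c(OC)c3)[nH]n2)cc1OC` gives 10600 nM in this assay, a value within the scatter of compound 3. Compound 1 `COc1cc(-c2cc(/C=C/C(=O)c3ccc(Cl)c(Cl)c3)[nH]n2)cc(OC)c1OC` reaches only the limit of the assay, > 100000 nM. Within the data shown here, the single measured step on the ring at the carbonyl carbon, an at least 16-fold lower number from compound 1 to compound 3 (1.20 log units; beyond the scatter), is large, but it exchanges the whole ring rather than adding one group. Compound 4 `COc1cc(C(=O)/C=C/c2cc(-c3cc(OC)c(OC)c(OC)c3)n[nH]2)cc(OC)c1OC` differs from compound 3 by methoxy in place of hydrogen on an aromatic carbon. Compound 2 already holds a methoxy in that same place, and its value sits within the scatter of compound 3, so no step beyond the scatter is expected. Compound 4 is estimated at 6000 nM, between 2000 nM and 20000 nM. The expected step is a 1.0-fold lower number from compound 3 to compound 4 (0.02 log units; within the scatter).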

Compound 4, concentration lethal to 50% of the cells: 6070 nM
For compound 4 the middle estimate is 1.0-fold (0.01 log units) below the measured one; the measured number falls inside the stated range.
By their numbers in this assay, from the lowest: compounds 4, 3 and 2 (each within the scatter of the next). At a limit, above all of these: compound 1.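

A methoxy in place of hydrogen on the ring at the carbonyl carbon gives a 1.0-fold lower number from compound 3 to compound 4 (0.01 log units; within the scatter), so this position takes the extra group with no change beyond the scatter. The same exchange on the other ring gives a 1.7-fold lower number from compound 2 to compound 4 (0.24 log units; within the scatter), also within the scatter, which means that compound 4, with methoxy in both places, stands level with both of its neighbours. Nothing shown gives a reason for this flat result. On these data alone, whether an amine, a hydroxy group or a longer chain in this place would move the number beyond the scatter remains open.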